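The source may report more compounds than this note shows. Statements on the series, on what has been measured and on what is new or still open speak of the compounds shown alone.

Three compounds have been measured in an assay on HEK293 cells for inhibition of solute carrier family 22 member 12 (Homo sapiens); a higher number here means a weaker inhibitor, a lower number a stronger inhibitor:

compound 1, `NS(=O)(=O)CSc1nnc(Br)n1Cc1ccc(Br)c2ccccc12`, giving 365000 nM
compound 2, `O=S(=O)(O)CSc1nnc(Br)n1Cc1ccc(Br)c2ccccc12`, giving 14400 nM
compound 3, `O=S(=O)(CSc1nnc(Br)n1Cc1ccc(Br)c2ccccc12)Nc1cccnc1`, giving 32 nM

Compound 3 stands lowest of the three numbers. The steps leading to it are large: a 25-fold lower number from compound 1 to compound 2 (1.40 log units; beyond the scatter), an 11000-fold lower number from compound 1 to compound 3 (4.06 log units; beyond the scatter) and a 450-fold lower number from compound 2 to compound 3 (2.65 log units; beyond the scatter). All three of these steps concern the group on the sulfonyl sulfur; none of them touches the aromatic ring attached to the sulfonamide nitrogen once it is in place.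

Compound 4, `O=S(=O)(CSc1nnc(Br)n1Cc1ccc(Br)c2ccccc12)Nc1cncc(C(F)(F)F)c1`, differs from compound 3 by trifluoromethyl in place of hydrogen on an aromatic carbon. Going by the values given here, no measured step bears directly on this kind of change, since the measured steps all exchange the sulfonyl substituent itself rather than decorate the pyridine ring. Without such a precedent, the expected step from compound 3 to compound 4 is a 1.1-fold lower number from compound 3 to compound 4 (0.03 log units; within the scatter), which is not taken to lie beyond the scatter.

In this assay compound 4 is therefore estimated at 30 nM, with a plausible range from 8 nM to 120 nM.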

Compound 4, half-maximal inhibitory concentration: 6380 nM
For compound 4 the middle estimate is 210-fold (2.33 log units) below the measured one, outside the stated range (above it).
By their numbers in this assay, from the lowest: compound 3; then compound 4; then compound 2; then compound 1.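

In this assay, the pyridine ring of compound 3 proves not to be a neutral place for substitution: trifluoromethyl on this aromatic carbon, two atoms from the ring nitrogen, gives a 200-fold higher number from compound 3 to compound 4 (2.30 log units; beyond the scatter), undoing most of what the (pyridin-3-yl)amino group had gained. The (5-(trifluoromethyl)pyridin-3-yl)amino group retains only a modest edge over hydroxy on the sulfonyl sulfur, with a 2.3-fold lower number from compound 2 to compound 4 (0.35 log units; beyond the scatter), while 5-(trifluoromethyl)pyridin-3-yl on the sulfonamide nitrogen still gives a 57-fold lower number from compound 1 to compound 4 (1.76 log units; beyond the scatter). Nothing available explains the loss.

On these data alone, it remains open whether a smaller group on this carbon, such as a methyl, a chlorine or a methoxy, would cost as much as trifluoromethyl. Also open, as far as these compounds go, is how trifluoromethyl would fare on another carbon of the pyridine ring.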